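The source may hold more compounds than are shown below. What is called first, only, known or untested is meant among the compounds shown, and "the series" means these compounds.

Measured so far in a functional assay on Hep 3B2 cells (Homo sapiens) for cytotoxicity, read by MTT assay, with a stated time of 6 days; on this read-out lower numbers stand for stronger inhibition and higher numbers for weaker inhibition:
- compound 1 `Cc1ccc2c(c1)N(Cc1cn(Cc3ccccc3)nn1)C(=O)CO2`: > 100000 nM (a limit)
- compound 2 `COc1ccc2c(c1)N(Cc1cn(Cc3ccccc3)nn1)C(=O)CO2`: > 100000 nM (a limit)

In this assay compound 1 has no number, only the limit > 100000 nM. Among the measured compounds shown here, the same holds across the series so far, which stands at the limit of > 100000 nM in this assay, at which 2 of the 2 values shown sit. For the measured compounds named here, the only measured step is a step that the two limits leave unreadable from compound 1 to compound 2, so no size can be carried over from it.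

Compound 3 `CCOC(=O)c1ccc2c(c1)N(Cc1cn(Cc3ccccc3)nn1)C(=O)CO2` has ethoxycarbonyl in place of methyl on an aromatic carbon. This is a larger group than the methoxy of compound 2, but the data give no measure of what such a change does in this assay. Compound 2 also returned only a limit, > 100000 nM, so a change on this aromatic carbon is not expected to produce a clear gain. The estimated step is a number no higher from compound 1 to compound 3 (the limit leaves the size open), and no step beyond the usual scatter is expected in either direction. For compound 3 the estimate is 100000 nM, with an expected range of 30000 nM to 300000 nM, and another reading at the limit is the likeliest outcome.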

Compound 3, half-maximal inhibitory concentration: 17100 nM
Compound 3: the middle estimate sits 5.8-fold (0.77 log units) above what was measured, outside the stated range (below it).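

In this assay, among the compounds shown here, this aromatic carbon, meta to a fused ring and para to a fused ring, is the first place where a change brings the read-out off the limit. Ethoxycarbonyl in place of methyl gives an at least 5.8-fold lower number from compound 1 to compound 3 (0.76 log units; beyond the scatter), and ethoxycarbonyl in place of methoxy gives an at least 5.8-fold lower number from compound 2 to compound 3 (0.76 log units; beyond the scatter); the position can therefore affect the read-out, which the unreadable step between the two earlier limits could not show. Both steps give only a minimum size, because neither starting compound has a number, only a limit: the limit of > 100000 nM in this assay, at which 2 of the 3 values shown sit.

The compounds shown leave open whether the carbonyl, the ethyl end of the ethoxycarbonyl or the larger group as a whole accounts for the lower number, and whether a carboxylic acid, a primary amide or methoxycarbonyl on this carbon would keep it. Also open, from the compounds shown here alone, is whether a nitrile or an acetyl group in the same place would give a step of similar size.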